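From Methyl to Amino: Expecting Compound 4

The source may hold more compounds than are shown below. What is called first, only, known or untested is meant among the compounds shown, and "the series" means these compounds.

Compound 1 `Cc1nnc(SCc2coc3ccccc3c2=O)s1` holds the lower of the two numbers recorded in a functional assay on MDA-MB-435S cells (Homo sapiens) for cytotoxicity, read by MTT assay, with a stated time of 72 h (on this read-out higher numbers stand for weaker inhibition and lower numbers for stronger inhibition), where compound 1 gives 630 nM. Among the compounds with values here, its nearest neighbour, compound 3 `Cc1nnc(SCc2coc3ccc(Cl)cc3c2=O)s1`, gives 2200 nM in this assay, and the single measured step, a 3.5-fold higher number from compound 1 to compound 3 (0.54 log units; beyond the scatter), is modest though beyond the scatter. Compound 2 `Cc1cc(O)cc2oc(=O)cc(CSc3nc4ccccc4[nH]3)c12` gives > 25000 nM in this assay, which is the limit of > 25000 nM in this assay, at which 1 of the 3 values shown sits, and so a limit rather than a number.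

Compound 4 `Nc1nnc(SCc2coc3ccccc3c2=O)s1` differs from compound 1 by amino in place of methyl on an aromatic carbon. Within the data shown here, none of the measured steps touches this five-membered ring; the one step recorded, from compound 1 to compound 3, alters a different part of the shared core, so it offers no direct guide. With no evidence for this position, the change is expected to stay near the scatter or to weaken inhibition slightly in this assay. Compound 4 is therefore estimated at 1000 nM, with a range from 300 nM to 4000 nM, which means an expected step of a 1.6-fold higher number from compound 1 to compound 4 (0.20 log units; within the scatter).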

Compound 4, half-maximal inhibitory concentration: 950 nM
Estimate against measurement, compound 4: 1.1-fold (0.02 log units) above; the measured number falls inside the stated range.
By their numbers in this assay, from the lowest: compounds 1 and 4 (each within the scatter of the next); then compound 3. At a limit, above all of these: compound 2.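

In this assay, within the data shown here, the first measured step on this five-membered ring is a 1.5-fold higher number from compound 1 to compound 4 (0.18 log units; within the scatter), so 5-amino-1,3,4-thiadiazol-2-yl and 5-methyl-1,3,4-thiadiazol-2-yl cannot be told apart here. The exchange adds a hydrogen-bond donor and a hydrogen-bond acceptor to the count at this aromatic carbon, yet the step stays within the scatter, whereas the chloro step, a 3.5-fold higher number from compound 1 to compound 3 (0.54 log units; beyond the scatter), lies beyond it. Nothing shown gives a reason for this outcome, and the one recorded limit does not bear on it.

Only methyl and amino are shown at this aromatic carbon, so it remains open how a larger group, such as a dimethylamino group or a carboxylic acid, would read in this assay. On these data alone, it is also open whether amino would give a similar result alongside the chloro of compound 3.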